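Chain-length and hydroxymethyl variation at the branching carbon

The compounds below may be only part of what the source reports. "The series", "measured", "known", "first", "only" and "open" are said of these compounds alone.

Measured so far in an in vitro functional assay on cells for agonist activity at Bombesin receptor subtype-3 (Homo sapiens), read by luminescence and calcium flux; a higher number here means that more compound is needed for the effect, a lower number that less compound is needed:
compound 1 `CCCCc1cnc(C(CCC)Cc2ccc(-c3ccccc3C(=O)O)cc2)[nH]1`: 1180 nM
compound 2 `CCCCc1cnc(C(CCCC)Cc2ccc(-c3ccccc3C(=O)O)cc2)[nH]1`: 2660 nM
compound 3 `CCCCc1cnc(C(CC)Cc2ccc(-c3ccccc3C(=O)O)cc2)[nH]1`: 2720 nM

Compound 3 gives the highest of the three numbers, but its step to compound 2 is within the scatter, so the two cannot be told apart; only compound 1 sits clearly apart, with a 2.3-fold higher number from compound 1 to compound 3 (0.36 log units; beyond the scatter) separating it from compound 3.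

Compound 4 `CCCCc1cnc(C(CCCO)Cc2ccc(-c3ccccc3C(=O)O)cc2)[nH]1` is not yet measured. It differs from compound 3 by hydroxymethyl in place of hydrogen on a saturated chain carbon, three bonds along the chain from an aromatic carbon. Within the data shown here, the nearest precedent is the step from compound 3 back to compound 1, which carries a methyl at the same carbon: a 2.3-fold higher number from compound 1 to compound 3 (0.36 log units; beyond the scatter), so a single carbon there lowers the number beyond the scatter. The longer chain of compound 2 does not repeat this: a 1.0-fold higher number from compound 2 to compound 3 (0.01 log units; within the scatter) and a 2.3-fold higher number from compound 1 to compound 2 (0.35 log units; beyond the scatter). Among the measured compounds shown here, no measured compound carries a hydroxyl anywhere, so the effect of the oxygen is not covered by these data.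

Compound 4 is therefore expected to land between compound 3 and compound 1, a step of a 1.5-fold lower number from compound 3 to compound 4 (0.18 log units; within the scatter), with a wide range. The estimate for compound 4 is 1800 nM, between 600 nM and 5500 nM.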

Compound 4, half-maximal effective concentration: 1900 nM
Beside the measured number, compound 4's estimate is 1.1-fold (0.02 log units) below it; the measured number falls inside the stated range.
By their numbers in this assay, from the lowest: compounds 1, 4, 2 and 3 (each within the scatter of the next, the first and the last beyond it).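

In this assay the first hydroxyl in the series gives a compound that cannot be told apart from any of the three chain analogues, with a 1.4-fold lower number from compound 3 to compound 4 (0.16 log units; within the scatter) and a 1.4-fold lower number from compound 2 to compound 4 (0.15 log units; within the scatter) and a 1.6-fold higher number from compound 1 to compound 4 (0.21 log units; within the scatter) all read together. Compound 4 therefore stands within the scatter of both compound 1 and compound 3, although those two are separated by a 2.3-fold higher number from compound 1 to compound 3 (0.36 log units; beyond the scatter) and so the 3-hydroxypropyl chain cannot be assigned to the level of either. On this saturated chain carbon, ethyl to 3-hydroxypropyl is a change that the assay readout accommodates without a step beyond the scatter, and no measurement at hand offers an explanation for the value of compound 4.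

From the compounds shown here alone, whether an amine, a methoxy group or a carboxylic acid in place of the hydroxy would stay within the scatter of compound 4 remains open. With a single hydroxyl-bearing compound, the contribution of the oxygen also cannot be separated from that of chain length, and a longer chain ending in hydroxy would be needed to address this.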